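Swapping the Aryl Arm: From Compound 1 to Compound 3

The compounds below may be only part of what the source reports. "The series", "measured", "known", "first", "only" and "open" are said of these compounds alone.

Measured compounds:
Compound 1, `COc1cccc(/C=C/C(=O)c2ccc(OC)c3c2OC(C)(C)C=C3)c1`: > 10000 nM
Compound 2, `COc1ccc(C(=O)/C=C/c2ccc3ccccc3c2)c2c1C=CC(C)(C)O2`: 4480 nM

In a functional assay on HT-29 cells (Homo sapiens) for antiproliferative activity, read by MTT assay, with a stated time of 24 h (on this read-out higher numbers stand for weaker inhibition and lower numbers for stronger inhibition), compound 1 gives only a limit, > 10000 nM, and so sits at the limit of > 10000 nM in this assay, at which 1 of the 2 values shown sits. Compound 2 gives a number in this assay, 4480 nM, which shows that a change of the aryl arm on the shared core can bring the inhibition within the measurable range. Compound 3, `COc1ccc(C(=O)/C=C/c2cccs2)c2c1C=CC(C)(C)O2`, differs from compound 1 by thiophen-2-yl in place of 3-methoxyphenyl on a double-bonded chain carbon bound to a double-bonded chain carbon. Going by the values given here, no measured pair here shows the size of such a change, so the direction of the step is open; the thiophen-2-yl compound may stay at the limit or, like compound 2, fall just inside the range. Compound 3 is expected to show about 8000 nM, between 2500 nM and 30000 nM. The expected step of an at least 1.2-fold lower number from compound 1 to compound 3 (0.09 log units; that floor lies within the scatter) is a small gain, no more than the usual scatter.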

Compound 3, half-maximal inhibitory concentration: > 10000 nM
Compound 3: no number, only a limit; the forecaster's own chance of this, stated with the estimate: 45%; at least 1.2-fold (0.09 log units) between middle value and limit.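

In this assay, going by these compounds alone, compound 3, like compound 1, gives only a limit, so no step between compound 1 and compound 3 can be read, and that limit is shared: the limit of > 10000 nM in this assay, at which 2 of the 3 values shown sit. The compounds shown leave open whether thiophen-2-yl and 3-methoxyphenyl differ at all in inhibition on the shared core.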